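Urea hydroxamates: phenyl to benzyl on compound 2

The source may hold more compounds than are shown below. What is called first, only, known or untested is meant among the compounds shown, and "the series" means these compounds.

Measured so far in a functional assay on A549 cells (Homo sapiens) for inhibition, read by sulforhodamine B assay, with a stated time of 48 h; on this read-out higher numbers stand for weaker inhibition and lower numbers for stronger inhibition:
- Compound 1 `O=C(CCCC(=O)Nc1ccc(NC(=O)Nc2ccc(Cl)c(C(F)(F)F)c2)cc1)NO`: > 10000 nM, a limit of the assay and not a number.
- Compound 2 `O=C(Nc1ccc2c(c1)CCN2c1ccc(C(=O)NO)cc1)Nc1ccc(Cl)c(C(F)(F)F)c1`: 3400 nM

Among the measured compounds shown here, compound 2, at 3400 nM, holds the only actual number so far. Compound 1 stands at a limit: the limit of > 10000 nM in this assay, at which 1 of the 2 values shown sits. For the measured compounds named here, no step between measured compounds that differ in one place is available, so there is no measured guide to the size of the next change.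

Compound 3 `O=C(Nc1ccc2c(c1)CCN2Cc1ccc(C(=O)NO)cc1)Nc1ccc(Cl)c(C(F)(F)F)c1` keeps the shared core of compound 2 and differs in one place: 4-(hydroxycarbamoyl)benzyl in place of 4-(hydroxycarbamoyl)phenyl on a nitrogen on an aromatic ring in a ring. In words, 4-(hydroxycarbamoyl)benzyl stands in place of 4-(hydroxycarbamoyl)phenyl on a nitrogen on an aromatic ring in a ring.

In this assay, a modest step towards stronger inhibition is expected, starting from compound 2 at 3400 nM, though a result within the usual scatter would not be surprising. The estimated change is a 2.3-fold lower number from compound 2 to compound 3 (0.36 log units; beyond the scatter). Compound 3 is expected at about 1500 nM, with an estimated range of 400 nM to 6000 nM.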

Compound 3, half-maximal inhibitory concentration: 3100 nM
Compound 3: middle estimate off by 2.1-fold (0.32 log units), on the low side; the range from low to high includes it.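

Among the compounds shown here, putting 4-(hydroxycarbamoyl)benzyl in place of 4-(hydroxycarbamoyl)phenyl on a nitrogen on an aromatic ring in a ring gives the first step that can be read in this assay: a 1.1-fold lower number from compound 2 to compound 3 (0.04 log units; within the scatter). The entering group has one more carbon than the group it replaces, and at this position that change does not separate compound 2 from compound 3, so the two cannot be ranked on this read-out. For the compounds shown here, compound 1 remains a limit and not a number, and no step links it to the other compounds, so it adds no size of effect to this comparison: the limit of > 10000 nM in this assay, at which 1 of the 3 values shown sits.

Going by these compounds alone, one step within the scatter shows only that this single exchange leaves the read-out in place, and it does not show whether other groups on this nitrogen would do the same. Open questions are how a longer chain, as in 4-(hydroxycarbamoyl)phenethyl, would read at this nitrogen, and whether a carboxylic acid in place of the hydroxycarbamoyl group would keep any inhibition in this assay.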